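Amide carbonyl substituent variation on a trimethoxyanilide series

This account rests on a few compounds, and the source may have more. Where it says the series, first, only, none or still open, it means among the compounds named here.

Compounds measured in a functional assay on KYSE-450 cells (Homo sapiens) for inhibition, read by MTT assay, with a stated time of 48 h; on this read-out higher numbers stand for weaker inhibition and lower numbers for stronger inhibition:
- compound 1 `COCC(=O)N(Cc1ccc(OC)c(O)c1)c1cc(OC)c(OC)c(OC)c1` gives 460 nM
- compound 2 `C=C(C)C(=O)N(Cc1ccc(OC)c(O)c1)c1cc(OC)c(OC)c(OC)c1` gives 200 nM
- compound 3 `C/C=C/C=C/C(=O)N(Cc1ccc(OC)c(O)c1)c1cc(OC)c(OC)c(OC)c1` gives 180 nM

Compound 3 holds the lowest number of the three in this assay; its gap to compound 2 lies within the scatter, while compound 1 sits clearly higher. The relevant steps are a 2.3-fold lower number from compound 1 to compound 2 (0.36 log units; beyond the scatter) and a 2.6-fold lower number from compound 1 to compound 3 (0.41 log units; beyond the scatter), both modest, against a 1.1-fold lower number from compound 2 to compound 3 (0.05 log units; within the scatter), which is within the scatter.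

Compound 4 `COc1ccc(CN(C(=O)CO)c2cc(OC)c(OC)c(OC)c2)cc1O` carries the change (hydroxymethyl in place of penta-1,3-dien-1-yl on a carbonyl carbon). Hydroxymethyl stands nearer to the methoxymethyl of compound 1 than to the penta-1,3-dien-1-yl of compound 3, so a number expected near that of compound 1 is reasonable, i.e. a modest rise, a 2.8-fold higher number from compound 3 to compound 4 (0.44 log units; beyond the scatter). Compound 4 is therefore estimated at 500 nM, in a range from 200 nM to 1300 nM.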

Compound 4, half-maximal inhibitory concentration: 370 nM
Compound 4: middle estimate off by 1.4-fold (0.13 log units), on the high side; measured number inside the range.
By their numbers in this assay, from the lowest: compounds 3, 2, 4 and 1 (each within the scatter of the next, the first and the last beyond it).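

Hydroxymethyl on the carbonyl carbon stays apart from penta-1,3-dien-1-yl (a 2.1-fold higher number from compound 3 to compound 4 (0.31 log units; beyond the scatter)), a modest step. Hydrogen in place of methyl on the oxygen of methoxymethyl gives no readable difference (a 1.2-fold lower number from compound 1 to compound 4 (0.09 log units; within the scatter)), so compound 4 and compound 1 cannot be told apart in this assay. Compound 4 also cannot be told apart from compound 2 (a 1.9-fold higher number from compound 2 to compound 4 (0.27 log units; within the scatter)), although compound 1 and compound 2 do separate, so the two hydroxymethyl steps do not sort the groups cleanly. No measured evidence accounts for these steps. Open, from the compounds shown here alone, is how an aminomethyl group or a carboxylic acid on the carbonyl carbon would read.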